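Carbamate to amide at the aromatic amine

The source may hold more compounds than are shown below. What is called first, only, known or untested is meant among the compounds shown, and "the series" means these compounds.

Compound 1 `COc1ccc(S(=O)(=O)N2CCc3cccc(NC(=O)Oc4ccccc4)c32)cc1` carries a phenoxycarbonyl on a nitrogen on an aromatic ring of the shared core. In a functional assay on MKN-45 cells (Homo sapiens) for cytotoxicity (a higher number here means a weaker inhibitor, a lower number a stronger inhibitor), compound 1 gives > 10000 nM, which is a limit of the assay rather than a number, so its standing among the measured compounds is set only by that limit (the limit of > 10000 nM in this assay, at which 1 of the 3 values shown sits). Compound 2 `COc1ccc(S(=O)(=O)N2CCc3cccc(N)c32)cc1` gives 1200 nM in this assay, and compound 3 `COc1ccc(C(=O)Nc2cccc3c2N(S(=O)(=O)c2ccc(OC)cc2)CC3)cc1` gives 1600 nM. The two steps out of compound 1 both lower the number: an at least 8.3-fold lower number from compound 1 to compound 2 (0.92 log units; beyond the scatter) and an at least 6.2-fold lower number from compound 1 to compound 3 (0.79 log units; beyond the scatter). Between the free amine and the amide the values sit close: a 1.3-fold higher number from compound 2 to compound 3 (0.12 log units; within the scatter).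

Compound 4 `COc1ccc(S(=O)(=O)N2CCc3cccc(NC(=O)c4ccc(C#N)cc4)c32)cc1` differs from compound 1 by 4-cyanophenyl in place of phenoxy on a carbonyl carbon. The closest measured step is the move from compound 1 to compound 3, where a 4-methoxyphenyl also replaced phenoxy on the carbonyl carbon and the number fell by at least modest size. A step of like direction is expected here: an at least 6.6-fold lower number from compound 1 to compound 4 (0.82 log units; beyond the scatter). In this assay compound 4 is therefore expected to give 1500 nM, with a range from 400 nM to 6000 nM.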

Compound 4, half-maximal inhibitory concentration: 89 nM
Estimate against measurement, compound 4: 17-fold (1.23 log units) above, outside the stated range (below it).
By their numbers in this assay, from the lowest: compound 4; then compounds 2 and 3 (each within the scatter of the next). At a limit, above all of these: compound 1.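

In this assay, the group on the amide carbonyl proves to matter: cyano in place of methoxy on an aromatic carbon gives an 18-fold lower number from compound 3 to compound 4 (1.25 log units; beyond the scatter). Acylating the aromatic amine can therefore pay, with a 13-fold lower number from compound 2 to compound 4 (1.13 log units; beyond the scatter), although compound 3 stayed within the scatter of compound 2. The step out of the carbamate, an at least 110-fold lower number from compound 1 to compound 4 (2.05 log units; beyond the scatter), is only a bound, as compound 1 stands at a limit: the limit of > 10000 nM in this assay, at which 1 of the 4 values shown sits.

The values do not tell what lies behind the gain from cyano, since only the cyano and methoxy amides can be compared at this place. Going by these compounds, whether the gain is specific to the nitrile remains open, and a trifluoromethyl, a carboxylic acid or an aminomethyl on the same aromatic carbon would test that.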